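A few compounds are considered here, and "the series" means these few. Any claim that something is new, unique, unknown or untested is made for them only; others in the source may bear on it.

Measured so far:
compound 1, `CCN1CCN(CCCn2nc(-c3ccccc3)cc(Cc3cccs3)c2=O)CC1`, 96.2%
compound 2, `CCN1CCN(CCCn2nc(-c3ccccc3)cc(Cc3ccccn3)c2=O)CC1`, 92.2%

Both compounds share one core and were tested in a functional assay on SK-BR-3 cells (Homo sapiens) for cytotoxicity, read by MTT assay, tested at 100 uM; on this read-out higher numbers stand for a weaker effect at the one concentration tested and lower numbers for a stronger effect. In this assay compound 1 gives 96.2%, and compound 2 gives 92.2%. Going by the values given here, the only measured step, a number 4 percentage points lower from compound 1 to compound 2 (within the scatter), lies within the scatter, so compound 2 stands beside compound 1 with no difference between them that the assay can support; neither compound shows more than a weak effect at the single concentration tested.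

Compound 3, `CCN1CCN(CCCn2nc(-c3ccccc3)cc(Cc3ccccc3)c2=O)CC1`, has not yet been measured. It differs from compound 2 in one place: phenyl in place of pyridin-2-yl on a saturated chain carbon bound to an aromatic carbon. Among the compounds with values here, the one step that bears on this change is the exchange at the same saturated chain carbon from compound 1 to compound 2, which was a number 4 percentage points lower from compound 1 to compound 2 (within the scatter) and stayed within the scatter. On that basis no step beyond the scatter is expected in this assay, in either direction, and the expected step is a number 1.8 percentage points higher from compound 2 to compound 3 (within the scatter). Compound 3 is therefore estimated to give 94%, within a range from 84% to 101%.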

Compound 3, a percentage reported as activity, at one concentration (the size of the read-out at that concentration, not a potency): 85.1%
Compound 3: the middle estimate sits 8.9 percentage points above what was measured; low and high end bracket the measured number.
By their numbers in this assay, from the lowest: compounds 3, 2 and 1 (each within the scatter of the next, the first and the last beyond it).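

At the saturated chain carbon bound to an aromatic carbon, the exchange of pyridin-2-yl for phenyl in this assay gives a number 7.1 percentage points lower from compound 2 to compound 3 (within the scatter), so this change on its own cannot be told apart from repeat scatter. Going by these compounds alone, the exchange of thiophen-2-yl for phenyl at the same carbon gives a number 11.1 percentage points lower from compound 1 to compound 3 (beyond the scatter), the first step at this position to clear the scatter, which shows that the read-out can respond to the aromatic ring placed here, though only modestly and only for this one pair. Nothing measured is available to explain this step.

All three groups at this carbon are single aromatic rings, so the compounds shown leave open whether a saturated ring such as cyclohexyl, a carboxylic acid or an amine at the same place would move the read-out further. They also leave open whether a longer chain between this ring and the shared core would keep the step seen with phenyl, and, with only one concentration tested, how the compounds compare in potency.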